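The source may report more compounds than this note shows. Statements on the series, on what has been measured and on what is new or still open speak of the compounds shown alone.

Series notes. Compound 1 `Nc1nc(SCc2cccc(Br)c2)c2ncn([C@@H]3O[C@H](CO)[C@@H](O)[C@H]3O)c2n1` carries a 3-bromobenzyl on the sulfur; in an assay on isolated protein for binding affinity to Equilibrative nucleoside transporter 1 (Homo sapiens) (a lower number here means a stronger inhibitor, a higher number a weaker inhibitor), compound 1 gives 2880 nM. Among the compounds with values here, compound 2 `Nc1nc(SI)c2ncn([C@@H]3O[C@H](CO)[C@@H](O)[C@H]3O)c2n1` has iodo on that sulfur instead, and in this assay compound 2 gives 81300 nM, the higher of the two numbers so far; the step of a 28-fold higher number from compound 1 to compound 2 (1.45 log units; beyond the scatter) is the only measured comparison in the set. Compound 3 `Cc1cccc(CSc2nc(N)nc3c2ncn3[C@@H]2O[C@H](CO)[C@@H](O)[C@H]2O)n1` is not yet measured; relative to compound 2 the change is (6-methylpyridin-2-yl)methyl in place of iodo on a sulfur. This reverses the type of change seen from compound 1 to compound 2, since an aromatic-ring-bearing methyl group again takes the place of iodo on the sulfur. Within the data shown here, the one bearing step was large, so a large step downward is expected in this assay, about a 20-fold lower number from compound 2 to compound 3 (1.31 log units; beyond the scatter). Among the measured compounds shown here, for compound 3 the expected value in this assay is therefore 4000 nM, with a range of 1000 nM to 16000 nM; the pyridine ring in place of a benzene ring has no precedent here, so the range is kept wide.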

Compound 3, half-maximal inhibitory concentration: 11500000 nM
The estimate for compound 3 lay 2900-fold (3.46 log units) below the measured number, and the stated range ends below it.
By their numbers in this assay, from the lowest: compound 1; then compound 2; then compound 3.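

In this assay, an aromatic ring on a methyl group at the sulfur does not by itself give a lower number than iodo: (6-methylpyridin-2-yl)methyl in place of iodo gives a 140-fold higher number from compound 2 to compound 3 (2.15 log units; beyond the scatter). The ring itself therefore matters strongly at this position, as 6-methylpyridin-2-yl in place of 3-bromophenyl on the saturated chain carbon bound to the sulfur gives a 4000-fold higher number from compound 1 to compound 3 (3.60 log units; beyond the scatter), and iodo falls in the middle of the three rather than at the weak end. Nothing available accounts for this gap.

As far as these compounds go, whether the rise follows the ring nitrogen or the exchange of bromo for methyl stays open, since both change together in that step. Also open, from the compounds shown here alone, is how a plain benzyl group, or a longer chain ending in an amine, would read on the sulfur in this assay.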